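The compounds below may be only part of what the source reports. "The series", "measured", "known", "first", "only" and "open" are said of these compounds alone.

Compound 1, `COC(=O)CCSc1nc(C(F)(F)F)ccc1CNC(=O)C(C)c1ccc(NS(C)(=O)=O)c(F)c1`: 48.2 nM
Compound 2, `CC(C(=O)NCc1ccc(C(F)(F)F)nc1[S+]([O-])C1CCCCC1)c1ccc(NS(C)(=O)=O)c(F)c1`: "not active" (no number reported)

On these data alone, compound 2 has no single number to stand on in an assay on CHO-K1 cells for antagonist activity at transient receptor potential cation channel subfamily V member 1 (Homo sapiens), read by FLIPR; a higher number here means a weaker inhibitor, a lower number a stronger inhibitor: compound 2 is reported as "not active" (no number reported), so its place on the scale is unknown, and only compound 1, which gives 48.2 nM, offers a measured point with a number.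

Compound 3, `CC(C(=O)NCc1ccc(C(F)(F)F)nc1SCc1ccc(Cl)cc1)c1ccc(NS(C)(=O)=O)c(F)c1`, is reached from compound 2 by one change: a group of 9 heavy atoms (7 carbon, 1 sulfur, 1 chlorine; one six-membered aromatic ring of carbon only) in place of a group of 8 heavy atoms (6 carbon, 1 oxygen, 1 sulfur; one six-membered non-aromatic ring of carbon only), on an aromatic carbon

Within the data shown here, no step between two measured compounds matches this change, so its size cannot be read from the data. What can be said is that compound 2, carrying the group that leaves, showed no activity, while compound 1, carrying a sulfanyl group at the same place with a different chain, gave 48.2 nM. On that basis the step from compound 2 to compound 3 in this assay is expected to run toward stronger inhibition and to be larger than the scatter, since any measurable number would already mark a gain over compound 2. Compound 3 is estimated to give about 30 nM, within a range from 5 nM to 200 nM.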

Compound 3, inhibition constant: 8.7 nM
Estimate against measurement, compound 3: 3.4-fold (0.54 log units) above; low and high end bracket the measured number.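

In this assay, compound 3, with (4-chlorobenzyl)sulfanyl on the aromatic carbon next to the ring nitrogen, has a measured number, whereas compound 2, with its oxygen-bearing sulfur and non-aromatic carbon ring at that place, has none, so the group here can decide whether any activity is recorded at all. Placing 4-chlorophenyl instead of (methoxycarbonyl)methyl on the saturated chain carbon bound to a sulfur gives a 5.5-fold lower number from compound 1 to compound 3 (0.74 log units; beyond the scatter), a gain beyond the usual scatter, which shows that this sulfur-linked chain can end in an aromatic ring and still give a stronger inhibitor. No measurement at hand explains either difference.

On these data alone, the step from compound 2 to compound 3 alters the oxygen on sulfur and the ring together, so the share of each stays unknown, and a plain cyclohexylsulfanyl or a benzyl group carrying an oxygen on its sulfur would be needed to separate them. The compounds shown also leave open whether the chlorine matters, as an unsubstituted benzylsulfanyl or a 4-fluorobenzylsulfanyl group would test, and whether an oxygen or an amine nitrogen could replace the linking sulfur.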